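The source may report more compounds than this note shows. Statements on the series, on what has been measured and on what is new or still open speak of the compounds shown alone.

Compound 2 `Cc1ccc(S(=O)(=O)N(CCn2cc(CCCF)nn2)[C@@H](C(=O)NO)C(C)C)cc1` is the weaker of the two measured compounds: in an assay on isolated protein for inhibition of matrix metalloproteinase-9 (Homo sapiens), read by fluorescence, with a stated time of 30 min (on this read-out higher numbers stand for weaker inhibition and lower numbers for stronger inhibition), compound 2 gives 3 nM, while compound 1 `COc1ccc(S(=O)(=O)N(CCn2cc(CCCF)nn2)[C@@H](C(=O)NO)C(C)C)cc1` gives 0.07 nM. The single difference between them, methyl in place of methoxy on an aromatic carbon, moved the number by a 43-fold higher number from compound 1 to compound 2 (1.63 log units; beyond the scatter), a large loss of inhibition.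

Compound 3 `CC(C)[C@H](C(=O)NO)N(CCn1cc(CCCF)nn1)S(=O)(=O)c1ccc(OCCF)cc1` changes the same position again: 2-fluoroethoxy in place of methyl on an aromatic carbon. Within the data shown here, the only measured step that bears on this is the one from compound 1 to compound 2, which shows that exchanging an oxygen-linked group for a plain methyl at this aromatic carbon costs a great deal. Putting an oxygen-linked group back should therefore recover much of what was lost, although 2-fluoroethoxy is not the same group as methoxy, so a full return to the number of compound 1 is not certain.

Compound 3 is thus expected to give a clearly lower number, about 0.2 nM, within a range from 0.04 nM to 1.5 nM, a step of a 15-fold lower number from compound 2 to compound 3 (1.18 log units; beyond the scatter) toward stronger inhibition.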

Compound 3, half-maximal inhibitory concentration: 2 nM
The estimate for compound 3 lay 10-fold (1.00 log units) below the measured number; the whole stated range lies below it.
By their numbers in this assay, from the lowest: compound 1; then compounds 3 and 2 (each within the scatter of the next).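

Placing 2-fluoroethoxy on this aromatic carbon in place of methyl gives a 1.5-fold lower number from compound 2 to compound 3 (0.18 log units; within the scatter) in this assay, so having an oxygen attached to the ring at this position is not enough on its own to restore strong inhibition. Fluoromethyl in place of hydrogen on the saturated chain carbon bound to that oxygen gives a 29-fold higher number from compound 1 to compound 3 (1.46 log units; beyond the scatter), which shows that this position responds strongly to a change made beyond the oxygen and that, among the three groups shown here, the lowest number goes with methoxy. No available evidence explains this difference.

Going by these compounds, it remains open whether the large step from methoxy to 2-fluoroethoxy goes with the longer chain or with the fluorine, a question that a plain ethoxy group on the same core could help to separate. On these data alone, it is also open how other groups at this aromatic carbon, such as a hydroxy group, a chlorine atom or a longer propoxy chain, would compare with methoxy.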